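Amine tail variation on the anilinoquinazoline series

The source may hold more compounds than are shown below. What is called first, only, known or untested is meant among the compounds shown, and "the series" means these compounds.

Three compounds of a shared core differing in the amine at the end of the chain have numbers in a functional assay on DU-145 cells (Homo sapiens) for antiproliferative activity, read by MTT assay, with a stated time of 72 h; on this read-out higher numbers stand for weaker inhibition and lower numbers for stronger inhibition. Compound 1 `CCN(CC)CCCOc1cc2ncnc(Nc3ccc(C#N)cc3)c2cc1OC` gives 68900 nM in this assay. Compound 2 `COc1cc2c(Nc3ccc(C#N)cc3)ncnc2cc1OCCCN1CCCCC1` gives 24400 nM, the lower of the two numbers. For compound 3 `COc1cc2c(Nc3ccc(C#N)cc3)ncnc2cc1OCCCN1CCCCC1CCO` this assay reports only a limit, > 100000 nM (the limit of > 100000 nM in this assay, at which 1 of the 3 values shown sits). The step of a 2.8-fold lower number from compound 1 to compound 2 (0.45 log units; beyond the scatter) shows a ring amine in place of an open one lowering the number. The step of an at least 4.0-fold higher number from compound 2 to compound 3 (0.61 log units; beyond the scatter) shows that adding a substituent on that ring raises it.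

Compound 4 `COc1cc2c(Nc3ccc(C#N)cc3)ncnc2cc1OCCCN1CCc2ccccc2C1` carries the change (1,2,3,4-tetrahydroisoquinolin-2-yl in place of piperidin-1-yl on a saturated chain carbon, three bonds along the chain from an oxygen on an aromatic ring). Both measured steps bear on it: the ring-for-chain swap was modest and downward, whereas enlarging the ring amine was at least modest and upward. The larger amine of compound 4 leans toward the latter pattern, so a small rise or nothing beyond the scatter is expected in this assay. The step of a 1.4-fold higher number from compound 2 to compound 4 (0.16 log units; within the scatter) is the estimate. Compound 4 is expected near 35000 nM, between 12000 nM and 100000 nM.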

Compound 4, half-maximal inhibitory concentration: > 100000 nM
Compound 4: no number, only a limit (the forecaster's own chance of this, stated with the estimate: 25%); middle value at least 2.8-fold (0.45 log units) from the limit.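

With an at least 4.0-fold higher number from compound 2 to compound 4 (0.61 log units; beyond the scatter) in this assay, the rise seen with the 2-hydroxyethyl group of compound 3 also appears with 1,2,3,4-tetrahydroisoquinolin-2-yl, an added ring with 0 hydrogen-bond donors. Against the open amine, the reading is an at least 1.4-fold higher number from compound 1 to compound 4 (0.16 log units; that floor lies within the scatter), so no order between diethylamino and 1,2,3,4-tetrahydroisoquinolin-2-yl can be claimed. Compound 4 gives a limit and not a number, and the step between compound 3 and compound 4 cannot be read, as both stand at the same limit: the limit of > 100000 nM in this assay, at which 2 of the 4 values shown sit.

From the compounds shown here alone, how far either compound lies past that limit remains open, so the two changes to piperidin-1-yl cannot be ranked. Going by these compounds, compound 2 gives 24400 nM, and whether pyrrolidin-1-yl, morpholin-4-yl or a longer chain carrying piperidin-1-yl would give a lower number is also open.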